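An Aromatic Group Exchange from Compound 3 to Compound 4

A few compounds are considered here, and "the series" means these few. Any claim that something is new, unique, unknown or untested is made for them only; others in the source may bear on it.

In an ADME assay on Caco-2 cells (Homo sapiens) for permeability, read by LC-MS, in the apical to basolateral direction, with a stated time of 2 h, tested at 2 uM (a higher number here means that the compound crosses the layer faster, a lower number that the compound crosses the layer more slowly), compound 3 `CC[C@@H](Nc1c(C#N)c(-c2ccc(-c3ccc(OC)cc3)cc2)nc2cnccc12)C(N)=O` gives 114 nm/s, within the scatter of compound 1 `CC[C@@H](Nc1c(C#N)c(-c2ccc(-c3ccccc3F)cc2)nc2cnccc12)C(N)=O` at 140 nm/s. Compound 2 `CCOc1ccccc1-c1ccc(-c2nc3cnccc3c(C[C@H](C)C(=O)O)c2C#N)cc1`, which also carries 2-ethoxyphenyl but has a different side chain, gives a lower 43 nm/s, beyond the scatter of compound 3. Compound 4 `CCOc1ccccc1-c1ccc(-c2nc3cnccc3c(N[C@H](CC)C(N)=O)c2C#N)cc1` has 2-ethoxyphenyl in place of 4-methoxyphenyl on an aromatic carbon. Going by the values given here, the one measured step exchanging a group at this place is a 1.2-fold lower number from compound 1 to compound 3 (0.09 log units; within the scatter), so no shift beyond the scatter is expected in this assay. The expected step is a 1.0-fold lower number from compound 3 to compound 4 (0.02 log units; within the scatter). For compound 4 the estimate is 110 nm/s, with an expected range from 55 nm/s to 200 nm/s.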

Compound 4, apparent permeability: 151 nm/s
For compound 4 the middle estimate is 1.4-fold (0.14 log units) below the measured one, and the stated range covers the measured number.
By their numbers in this assay, from the lowest: compound 2; then compounds 3, 1 and 4 (each within the scatter of the next).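

In this assay, the exchange of 4-methoxyphenyl for 2-ethoxyphenyl gives a 1.3-fold higher number from compound 3 to compound 4 (0.12 log units; within the scatter), and ethoxy in place of fluoro gives a 1.1-fold higher number from compound 1 to compound 4 (0.03 log units; within the scatter), so all three aromatic groups at this place now lie within the scatter of one another. Going by these compounds alone, with 2-ethoxyphenyl held constant, (1-carbamoylpropyl)amino in place of 2-carboxypropyl gives a 3.5-fold higher number from compound 2 to compound 4 (0.55 log units; beyond the scatter), which places the only step beyond the scatter at the side chain. No supporting evidence accounts for either result. On these data alone, whether a dimethylamino group on this aromatic ring would shift the number remains open, as does which part of the side chain carries the step.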